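Removal of butylamino from compound 3

The compounds below may be only part of what the source reports. "The series", "measured", "known", "first", "only" and "open" are said of these compounds alone.

Compound 3 `CCCCNc1nc(N)c2nc(O)n(Cc3ccccc3)c2n1` stands as the lowest number among the two values available in a functional assay on the whole organism for activation, with Mus musculus as the target (a higher number here means that more compound is needed for the effect, a lower number that less compound is needed), where compound 3 gives 0.1 mg/kg. Its nearest neighbour, compound 1 `Nc1ncnc2c1nc(O)n2Cc1ccc(Cl)cc1`, gives 30 mg/kg in this assay. Compound 2 `Nc1nc(SCc2ccccc2)nc2c1nc(O)n2Cc1ccccc1` gives only a limit of the assay in this assay, > 1 mg/kg; the evidence is summarised as the limit of > 1 mg/kg in this assay, at which 1 of the 3 values shown sits.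

Compound 4 `Nc1ncnc2c1nc(O)n2Cc1ccccc1` is not yet measured. It differs from compound 3 by hydrogen in place of butylamino on an aromatic carbon.

Within the data shown here, the one measured step that touches the same aromatic carbon is the move from compound 2 to compound 3, an at least 10-fold lower number from compound 2 to compound 3 (1.00 log units; beyond the scatter), which shows that the butylamino group is tied to the low number of compound 3. Removing it is therefore expected to raise the number substantially. Compound 1, which also carries hydrogen in place of butylamino, sits far above compound 3 and serves as the anchor.

Compound 4 is expected to give about 30 mg/kg in this assay, within a range of 5 mg/kg to 150 mg/kg. The expected step is a 300-fold higher number from compound 3 to compound 4 (2.48 log units; beyond the scatter).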

Compound 4, minimum effective dose: 30 mg/kg
Compound 4: the middle estimate sits on the measured number at the digits printed; the measured number falls inside the stated range.
By their numbers in this assay, from the lowest: compound 3; then compounds 1 and 4 (each within the scatter of the next).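

Among these compounds, with only the butylamino group changed, a 300-fold higher number from compound 3 to compound 4 (2.48 log units; beyond the scatter) gives the first full reading at this aromatic carbon between two ring nitrogen atoms in this assay: the low number of compound 3 depends on that group, and hydrogen there does not retain it. Chloro in the other place makes no difference on this scaffold without butylamino, as no change at the digits printed from compound 1 to compound 4 (within the scatter) shows. Compound 2 is held only as a limit, so its step to compound 4 cannot be read: the limit of > 1 mg/kg in this assay, at which 1 of the 4 values shown sits.

Still open, on these data alone, is whether the low number of compound 3 rests on the amino nitrogen or on the butyl chain; butoxy or methylamino on the same carbon would separate the two. Also open, as far as these compounds go, is whether chloro stays without effect once butylamino is present.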